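Compound 3: inverting one stereocentre of compound 2

The source may hold more compounds than are shown below. What is called first, only, known or untested is meant among the compounds shown, and "the series" means these compounds.

- compound 1 (`O=C(NCCCCCNC(=O)C1=NO[C@]2(C=C(Br)C(=O)[C@@H](Br)[C@@H]2O)C1)C1=NO[C@]2(C=C(Br)C(=O)[C@@H](Br)[C@@H]2O)C1`): 2100 nM
- compound 2 (`COC1=C(Br)[C@H](O)[C@@]2(C=C1Br)CC(C(=O)NCCCCNC(=O)C1=NO[C@]3(C=C(Br)C(=O)[C@@H](Br)[C@@H]3O)C1)=NO2`): 5200 nM

In a functional assay on HT-29 cells (Homo sapiens) for cytotoxicity, read by sulforhodamine B assay (on this read-out lower numbers stand for stronger inhibition of growth and higher numbers for weaker inhibition of growth), compound 2 gives 5200 nM and holds the higher of the two numbers, so it is the weaker growth inhibitor of the pair. The gap to compound 1 at 2100 nM lies beyond the scatter. These two compounds differ in more than one place, so their gap says nothing about any single change.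

Compound 3 (`COC1=C(Br)[C@H](O)[C@@]2(C=C1Br)CC(C(=O)NCCCCNC(=O)C1=NO[C@]3(C=C(Br)C(=O)[C@H](Br)[C@@H]3O)C1)=NO2`) has the same atoms and bonds as compound 2 and differs only in configuration as drawn (the two compounds have the same atoms and bonds and differ only in configuration as drawn: 1 of 5 stereo elements differ; a stereocentre at a saturated ring carbon is drawn S in compound 2 and R in compound 3): a stereocentre at a saturated ring carbon is drawn S in compound 2 and R in compound 3. Among the measured compounds shown here, no measured pair isolates a change of this kind, so the data give no direct guide to its size. In this assay a step within the scatter is expected, with no direction favoured, although a larger move either way cannot be ruled out. The expected change is a 1.0-fold lower number from compound 2 to compound 3 (0.02 log units; within the scatter) on this read-out. For compound 3 the estimate is an expected value of 5000 nM (estimated range 2200 nM to 11000 nM).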

Compound 3, concentration for total growth inhibition: 4900 nM
The estimate for compound 3 lay 1.0-fold (0.01 log units) above the measured number, and the stated range covers the measured number.
By their numbers in this assay, from the lowest: compound 1; then compounds 3 and 2 (each within the scatter of the next).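

Inverting the stereocentre at a saturated ring carbon, drawn S in compound 2 and R in compound 3, gives in this assay a 1.1-fold lower number from compound 2 to compound 3 (0.03 log units; within the scatter), so the two compounds are not told apart on this read-out. Among the compounds shown here, this is the first pair that differs in one place only, and no atom or bond enters or leaves, so the comparison bears on configuration alone: the fact that compounds 2 and 3 differ only in the configuration as drawn. At this stereocentre, then, the configuration as drawn does not move growth inhibition in these cells by more than the usual scatter, and either form of the stereocentre is accommodated at this level of activity.

The compounds shown leave open whether the other stereo elements are equally silent, and whether this inversion would stay within the scatter in a compound carrying a longer chain or an amine. They also leave open whether the same holds on any other cell line or read-out, and the single inverted stereocentre says nothing about the gap that sets compound 1 apart.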